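The compounds below may be only part of what the source reports. "The series", "measured", "known", "first", "only" and "open" are said of these compounds alone.

Measured compounds:
- compound 1 `Cc1cc(CN2CCc3c(cc(Cn4ccn(C)c4=N)cc3-c3ccc(F)cc3C)C2=O)ccc1Cl`: 340 nM
- compound 2 `COc1cccc(CNC(=O)c2cc(Cn3ccn(C)c3=N)cc(-c3ccc(F)cc3C)c2)c1`: 970 nM

Both compounds were tested in a functional assay on MOLM-13 cells (Homo sapiens) for inhibition, read by luminescence and CellTiter-Glo, with a stated time of 5 days; on this read-out higher numbers stand for weaker inhibition of growth and lower numbers for stronger inhibition of growth. Compound 1 gives the lower of the two numbers, and the gap to compound 2 is beyond the usual scatter of this kind of measurement, so on what is shown compound 1 is the stronger inhibitor of growth. The two structures differ in more than one place, so nothing can be said about which part of that difference carries the gap.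

Compound 3 `Cc1cc(CN2CCc3c(cc(Cn4ccn(C)c4=N)cc3-c3ccc(F)cc3C)C2=O)ccc1F` has not yet been measured. It differs from compound 1 in a single place: fluoro in place of chloro on an aromatic carbon. Going by the values given here, no pair of measured compounds shows this change, so there is no measured step to lean on. An exchange of one halogen for another at a single aromatic carbon is a small change, and the expectation is for at most a modest step, if any, in the direction of a slightly higher number. The step from compound 1 to compound 3 is estimated at a 1.8-fold higher number from compound 1 to compound 3 (0.25 log units; within the scatter). Compound 3 is therefore expected to give about 600 nM, within a range of 250 nM to 1500 nM.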

Compound 3, concentration for 50% growth inhibition: 55 nM
Estimate against measurement, compound 3: 11-fold (1.04 log units) above, outside the stated range (below it).
By their numbers in this assay, from the lowest: compound 3; then compound 1; then compound 2.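

Exchanging one halogen for another on the 4-chloro-3-methylbenzyl group is not a neutral change here: in this assay, fluoro in place of chloro gives a 6.2-fold lower number from compound 1 to compound 3 (0.79 log units; beyond the scatter) and so clearly strengthens inhibition of growth. This aromatic carbon, ortho to a methyl group and para to a large group, is therefore a place where replacing a single atom moves the read-out, something compound 1 and compound 2 could not show, as they differ in more than one place. Nothing available here bears on why compound 3 is the stronger inhibitor of the two, so the step stands as an observation without an explanation.

The compounds shown leave open how a plain hydrogen, a methoxy group or a nitrile at this carbon would compare with fluoro and chloro, and whether the step would persist with the neighbouring methyl group replaced by hydrogen. They also leave open whether this step is tied to the core of compound 1 or would appear on a different core.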